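The source may hold more compounds than are shown below. What is called first, only, known or untested is meant among the compounds shown, and "the series" means these compounds.

Measured compounds:
compound 1 `C1=C(c2cncc(OCc3ccccc3)c2)CC2CNCC1C2`, 44 nM in an in vitro assay on SH-SY5Y cells for displacement of a labelled ligand from Neuronal acetylcholine receptor; alpha3/beta4 (Homo sapiens); a lower number here means a stronger inhibitor, a higher number a weaker inhibitor
compound 2 `FC(F)(F)c1cncc(C2=CC3CNCC(C2)C3)c1`, 79 nM
compound 3 `Clc1cccc(Oc2cncc(C3=CC4CNCC(C3)C4)c2)c1`, 22 nM

Compound 3 and compound 1 sit together at the lower end of these numbers, the step of a 2.0-fold lower number from compound 1 to compound 3 (0.30 log units; within the scatter) being within the scatter, while compound 2 stands clearly higher than compound 3. Compound 4 `COc1cncc(C2=CC3CNCC(C2)C3)c1` is not yet measured; it carries methyl in place of 3-chlorophenyl on an oxygen on an aromatic ring. Among the measured compounds shown here, no measured step bears directly on this change: only the exchange of benzyl for 3-chlorophenyl on the same oxygen is known, and it moved the number within the scatter. Compound 4 is therefore expected to give 60 nM, within 20 nM to 180 nM, a step of a 2.7-fold higher number from compound 3 to compound 4 (0.44 log units; beyond the scatter) that is estimated as a modest rise in the number.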

Compound 4, inhibition constant: 14.3 nM
Estimate against measurement, compound 4: 4.2-fold (0.62 log units) above, outside the stated range (below it).
By their numbers in this assay, from the lowest: compounds 4, 3, 1 and 2 (each within the scatter of the next, the first and the last beyond it).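

In this assay, methyl in place of 3-chlorophenyl on an oxygen on an aromatic ring gives a 1.5-fold lower number from compound 3 to compound 4 (0.19 log units; within the scatter), so among these compounds an aromatic ring on that oxygen is not needed for a number this low. Hydrogen in place of phenyl on the carbon bound to that oxygen gives a 3.1-fold lower number from compound 1 to compound 4 (0.49 log units; beyond the scatter), and methoxy in place of trifluoromethyl gives a 5.5-fold lower number from compound 2 to compound 4 (0.74 log units; beyond the scatter). Nothing given here explains these steps. The compounds shown leave open how an ethyl group, a longer chain or an amine on that oxygen would read.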